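Swapping a naphthalene for a chlorophenyl in stilbene-like cytotoxins

A few compounds are considered here, and "the series" means these few. Any claim that something is new, unique, unknown or untested is made for them only; others in the source may bear on it.

Measured so far:
compound 1, `COc1ccc(/C=C/c2cc(OC)c(OC)c(OC)c2-c2ccc3ccccc3c2)cc1`: 13000 nM
compound 2, `COc1ccc(/C=C/c2cc(OC)c(OC)c(OC)c2-c2ccc(Cl)cc2)cc1`: 49000 nM
compound 3, `C=C(c1ccc(OC)cc1)c1cc(OC)c(OC)c(OC)c1-c1ccc2ccccc2c1`: 35000 nM

All three were tested in a functional assay on HeLa cells (Homo sapiens) for cytotoxicity, read by MTT assay, with a stated time of 48 h; on this read-out higher numbers stand for weaker inhibition and lower numbers for stronger inhibition. Compound 1 gives the lowest number of the three. Compound 2 differs from it by 4-chlorophenyl in place of naphthalen-2-yl on an aromatic carbon, and the step of a 3.8-fold higher number from compound 1 to compound 2 (0.58 log units; beyond the scatter) shows a weakening. Compound 3 shares its atoms with compound 1 but joins them differently, (1-(4-methoxyphenyl)ethenyl in place of 2-(4-methoxyphenyl)ethenyl on an aromatic carbon), and the step of a 2.7-fold higher number from compound 1 to compound 3 (0.43 log units; beyond the scatter) is again a weakening. Compounds 2 and 3 lie within the scatter of each other.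

Compound 4, `C=C(c1ccc(OC)cc1)c1cc(OC)c(OC)c(OC)c1-c1ccc(Cl)cc1`, has not yet been measured in this assay. It differs from compound 3 by 4-chlorophenyl in place of naphthalen-2-yl on an aromatic carbon. Within the data shown here, this is the same kind of change as the one from compound 1 to compound 2, though the surroundings differ: here the place is ortho to a 1-(4-methoxyphenyl)ethenyl group, there it was ortho to a 2-(4-methoxyphenyl)ethenyl group. Because the earlier step of a 3.8-fold higher number from compound 1 to compound 2 (0.58 log units; beyond the scatter) weakened inhibition, a step of similar size is expected, a 3.1-fold higher number from compound 3 to compound 4 (0.50 log units; beyond the scatter), with some allowance for the different surroundings. Compound 4 is therefore estimated at 110000 nM, expected within 40000 nM to 300000 nM.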

Compound 4, half-maximal inhibitory concentration: 30000 nM
Compound 4: middle estimate off by 3.7-fold (0.56 log units), on the high side, outside the stated range (below it).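

The swap of naphthalen-2-yl for 4-chlorophenyl now gives a 1.2-fold lower number from compound 3 to compound 4 (0.07 log units; within the scatter), a step within the scatter, whereas the same swap on the core of compound 1 clearly weakened inhibition. The change therefore did not carry over from one core to the other with the same size: the same change on two cores in this assay, a 3.8-fold higher number (0.58 log units; beyond the scatter) from compound 1 to compound 2 and a 1.2-fold lower number (0.07 log units; within the scatter) from compound 3 to compound 4, 4.4-fold (0.64 log units) apart, beyond the scatter of two such steps. This shows that the outcome of the swap differs between a core bearing a 2-(4-methoxyphenyl)ethenyl group and one bearing a 1-(4-methoxyphenyl)ethenyl group, but it does not show why, and a single comparison of two steps gives no rule for the whole series.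

The compounds shown carry only naphthalen-2-yl or 4-chlorophenyl at this place, so it remains open how a phenyl ring bearing an amine or a carboxylic acid there would behave on either core. On these data alone, it also remains open whether the two cores would differ in the same way for any other replacement of naphthalen-2-yl.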